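A few compounds are considered here, and "the series" means these few. Any claim that something is new, unique, unknown or untested is made for them only; others in the source may bear on it.

Compound 1 `CC(C)c1cccc(C(C)C)c1OC(=O)NS(=O)(=O)N1CCOCC1` was tested in an assay on liver for inhibition of sterol O-acyltransferase 1 (Rattus norvegicus), using microsomes (on this read-out higher numbers stand for weaker inhibition and lower numbers for stronger inhibition), and returned only a limit, > 100000 nM; it stands at the limit of > 100000 nM in this assay, at which 1 of the 3 values shown sits. Two other carbamates carry a real number: compound 2 `Cc1cc(C(C)(C)C)c(OC(=O)NS(=O)(=O)NC(c2ccccc2)c2ccccc2)c(C(C)(C)C)c1` gives 11500 nM in this assay, and compound 3 `CCCCCCCCCCCCOS(=O)(=O)NC(=O)Oc1c(C(C)C)cccc1C(C)C` gives 13000 nM. Compound 4 `CC(C)c1cccc(C(C)C)c1OC(=O)NS(=O)(=O)Oc1ccccc1` differs from compound 1 by phenoxy in place of morpholin-4-yl on a sulfonyl sulfur. Among the measured compounds shown here, no measured pair shows this change directly. Compound 3, which also carries an oxygen-linked group on its sulfonyl sulfur, gives 13000 nM, and that value is the nearest guide. On that basis the step of an at least 5.0-fold lower number from compound 1 to compound 4 (0.69 log units; beyond the scatter) is expected to run toward stronger inhibition, beyond the scatter. Compound 4 is therefore estimated at 20000 nM in this assay, within 5000 nM to 100000 nM.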

Compound 4, half-maximal inhibitory concentration: > 50000 nM
Compound 4: only a limit was reported; the forecaster's own chance of this, stated with the estimate: 25%; at least 2.5-fold (0.39 log units) between middle value and limit.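

Compound 1 and compound 4 each returned only a limit, so the step between them cannot be read. The compounds shown leave open whether phenoxy in place of morpholin-4-yl changes inhibition in this assay at all.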